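Replacing Isopropyl with Phenyl on the Hydrazine Nitrogen

The compounds below may be only part of what the source reports. "The series", "measured", "known", "first", "only" and "open" are said of these compounds alone.

Compound 2 `Cc1ccccc1-c1nnc(NNC(C)C)s1` gives 54 mg/kg in a functional assay on the whole organism with Mus musculus as the target, with a stated time of 1 h (on this read-out higher numbers stand for an effect only at larger amounts of compound and lower numbers for an effect already at smaller amounts), the higher of the two numbers at hand; compound 1 `Cc1ccccc1-c1nnc(N(N)C(C)C)s1` gives 49 mg/kg, and the change a 1.1-fold higher number from compound 1 to compound 2 (0.04 log units; within the scatter) lies within the scatter. Compound 3 `Cc1ccccc1-c1nnc(NNc2ccccc2)s1` differs from compound 2 by phenyl in place of isopropyl on an amine nitrogen. Within the data shown here, the only measured step concerns a different position, so no measured step bears directly on this change. Compound 3 is therefore expected to show no step beyond the scatter, a 1.0-fold higher number from compound 2 to compound 3 (0.01 log units; within the scatter), with an estimate of 55 mg/kg and a range from 25 mg/kg to 120 mg/kg.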

Compound 3, dose for half-maximal effect: > 100 mg/kg
Compound 3: only a limit was reported; the forecaster's own chance of this, stated with the estimate: 10%; middle value at least 1.8-fold (0.25 log units) away from the limit.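

In this assay compound 3 is reported only as a limit, not as a number: the limit of > 100 mg/kg in this assay, at which 1 of the 3 values shown sits. Phenyl in place of isopropyl on this amine nitrogen is the first change here that can be read at this position, and it gives an at least 1.8-fold higher number from compound 2 to compound 3 (0.26 log units; that floor lies within the scatter). That floor lies within the scatter, so the step does not yet set the two compounds apart. Going by these compounds, whether methyl, a longer chain such as butyl, or benzyl on this nitrogen would shift the number stays open. On these data alone, how far compound 3 lies past its limit also stays open.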